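The compounds below may be only part of what the source reports. "The series", "measured", "known", "first", "only" and "open" are said of these compounds alone.

Measured so far:
- compound 1 `CN(CCC#N)C[C@H]1CN(c2ccc(-n3cc(-c4ccccn4)cn3)c(F)c2)C(=O)O1`: 64500 nM
- compound 2 `O=C1CSC(=O)N1C[C@H]1CN(c2ccc(-n3cc(-c4ccccn4)cn3)c(F)c2)C(=O)O1`: 26900 nM

Both compounds share one core and differ only in the group on a saturated chain carbon bound to a saturated ring carbon. In a physicochemical assay for solubility, read by HPLC, with a stated time of 24 h (on this read-out higher numbers stand for higher solubility and lower numbers for lower solubility), compound 1 gives 64500 nM, while compound 2 gives 26900 nM, the lower of the two numbers; the step of a 2.4-fold lower number from compound 1 to compound 2 (0.38 log units; beyond the scatter) was modest but beyond the scatter.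

Compound 3 `COC(=O)NC[C@H]1CN(c2ccc(-n3cc(-c4ccccn4)cn3)c(F)c2)C(=O)O1` has not yet been measured. Its change from compound 2 is (methoxycarbonyl)amino in place of 2,4-dioxo-1,3-thiazolidin-3-yl on a saturated chain carbon bound to a saturated ring carbon. Within the data shown here, no measured step involves (methoxycarbonyl)amino, so the only step known, a 2.4-fold lower number from compound 1 to compound 2 (0.38 log units; beyond the scatter), concerns a different exchange and bears on this one only loosely. On that basis no step beyond the scatter is firmly expected in this assay, though a small rise is thought somewhat more likely than a fall. The step from compound 2 to compound 3 is estimated at a 1.5-fold higher number from compound 2 to compound 3 (0.17 log units; within the scatter). Compound 3 is therefore expected to give about 40000 nM, within a range of 15000 nM to 110000 nM.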

Compound 3, solubility: 34100 nM
For compound 3 the middle estimate is 1.2-fold (0.07 log units) above the measured one, and the stated range covers the measured number.
By their numbers in this assay, from the lowest: compounds 2, 3 and 1 (each within the scatter of the next, the first and the last beyond it).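

On a saturated chain carbon bound to a saturated ring carbon, replacing 2,4-dioxo-1,3-thiazolidin-3-yl, which has a ring and no hydrogen-bond donor, with (methoxycarbonyl)amino, which has no ring and one donor, gives in this assay a 1.3-fold higher number from compound 2 to compound 3 (0.10 log units; within the scatter), so this exchange stays inside the usual scatter. Replacing (2-cyanoethyl)(methyl)amino with the same group gives a 1.9-fold lower number from compound 1 to compound 3 (0.28 log units; within the scatter), also inside the scatter, so compound 3 cannot be told apart from either neighbour, even though compound 1 and compound 2 are separated beyond the scatter. No measurement here offers an explanation for these numbers.

The three compounds leave open how a carboxylic acid or a simple primary amine at this place would read. They also leave open whether a longer chain on the carbamate oxygen would keep the number in this same range.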